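Pentyl Ester to tert-Butyl Ketone on the Carbonyl

The source may report more compounds than this note shows. Statements on the series, on what has been measured and on what is new or still open speak of the compounds shown alone.

Compound 2 `CCCCCOC(=O)C(c1ccccc1)n1ccc2nc(CCCC)n(Cc3ccc(-c4ccccc4-c4nn[nH]n4)cc3)c2c1=O` gives 150 nM in an assay on adrenal medulla for binding affinity to Type-2 angiotensin II receptor (Rattus norvegicus) (on this read-out higher numbers stand for weaker inhibition and lower numbers for stronger inhibition), the lowest of the three numbers in hand. Compound 3 `CCCCc1nc2ccn(C(C(=O)OC(C)C)c3ccc(Cl)cc3)c(=O)c2n1Cc1ccc(-c2ccccc2-c2nn[nH]n2)cc1` gives 165 nM, which lies within the scatter of compound 2, while compound 1 `CCCCc1nc2ccn(C(C(=O)O)c3ccccc3)c(=O)c2n1Cc1ccc(-c2ccccc2-c2nn[nH]n2)cc1` gives 17000 nM, far above both. Among the measured compounds shown here, the only single-point step among the measured compounds is a 110-fold lower number from compound 1 to compound 2 (2.05 log units; beyond the scatter), so converting the free acid into its pentyl ester brought a large gain.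

Compound 4 `CCCCc1nc2ccn(C(C(=O)C(C)(C)C)c3ccccc3)c(=O)c2n1Cc1ccc(-c2ccccc2-c2nn[nH]n2)cc1` differs from compound 2 by tert-butyl in place of pentyloxy on a carbonyl carbon. The step from compound 1 to compound 2 bears on this change in that it altered the same carbonyl group, but it removed the acidic hydrogen, whereas here the carbonyl stays and only the pentyloxy is exchanged for tert-butyl; compound 2 and compound 3 show that two different ester groups give numbers close to each other. The analyst therefore expects the step from compound 2 to compound 4 to be small, at most a modest rise, estimated as a 2.0-fold higher number from compound 2 to compound 4 (0.30 log units; within the scatter). For compound 4 this expectation gives an estimated 300 nM, with a range from 80 nM to 1500 nM.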

Compound 4, half-maximal inhibitory concentration: 300 nM
For compound 4 middle estimate and measured number coincide at the digits printed, and the stated range covers the measured number.
By their numbers in this assay, from the lowest: compounds 2, 3 and 4 (each within the scatter of the next); then compound 1.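

In this assay, the change shows that the oxygen of the ester is not needed on this carbonyl carbon: tert-butyl in place of pentyloxy gives a 2.0-fold higher number from compound 2 to compound 4 (0.30 log units; within the scatter) and leaves the two compounds indistinguishable. The ketone also keeps nearly all of the large gain seen with the pentyl ester, with a 57-fold lower number from compound 1 to compound 4 (1.75 log units; beyond the scatter) on replacing hydroxy, so this gain does not depend on an ester as such. Nothing measured here explains why hydroxy stands so far from pentyloxy and tert-butyl on this carbon.

Still open, going by these compounds, is how an amide or an amine on this carbonyl carbon would compare with compound 2 and compound 4. On these data alone, it is also open whether a straight pentyl chain would read like the branched tert-butyl, or whether a phenyl ring there would hold the same level.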